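Swapping a Chain for an Aromatic Ring

A few compounds are considered here, and "the series" means these few. Any claim that something is new, unique, unknown or untested is made for them only; others in the source may bear on it.

Compound 1 `CCCn1ccnc1-c1cc(OC)c(OC)c(OC)c1`: > 100000 nM (a limit)
Compound 2 `CCCCCn1ccnc1-c1cc(OC)c(OC)c(OC)c1`: > 100000 nM (a limit)

In a functional assay on HCT-15 cells (Homo sapiens) for antiproliferative activity, read by MTT assay, with a stated time of 72 h (a higher number here means a weaker inhibitor, a lower number a stronger inhibitor), compound 2 gives > 100000 nM, which is a limit and not a number. For the measured compounds named here, nothing better is known of the series so far: both compounds rest on (the limit of > 100000 nM in this assay, at which 2 of the 2 values shown sit). Going by the values given here, the only measured step is a step that the two limits leave unreadable from compound 1 to compound 2, so it offers no size to carry forward.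

Compound 3 `COc1cccc(-n2ccnc2-c2cc(OC)c(OC)c(OC)c2)c1` makes a different kind of change: 3-methoxyphenyl in place of pentyl on an aromatic nitrogen. Among the compounds with values here, no measured step covers an aromatic ring at this place, so the expectation is loose. With compound 2 at the limit of > 100000 nM, the only readable direction is toward a stronger inhibitor, although another limit remains quite possible. The estimated step is an at least 5.0-fold lower number from compound 2 to compound 3 (0.69 log units; beyond the scatter). For compound 3 the estimate is 20000 nM, with an expected range from 2000 nM to 100000 nM.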

Compound 3, half-maximal inhibitory concentration: 17100 nM
For compound 3 the middle estimate is 1.2-fold (0.07 log units) above the measured one; the measured number falls inside the stated range.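

In this assay, for the compounds shown here, compound 3 is the first compound with a value that is a number and not a limit, so a change on this aromatic nitrogen can move the read-out into a measurable range. Replacing the pentyl chain with the aromatic ring gives an at least 5.8-fold lower number from compound 2 to compound 3 (0.76 log units; beyond the scatter), and replacing the propyl chain gives an at least 5.8-fold lower number from compound 1 to compound 3 (0.76 log units; beyond the scatter); both steps are beyond the scatter, but each gives only a minimum size. Only the two chains remain at a limit: the limit of > 100000 nM in this assay, at which 2 of the 3 values shown sit.

The compounds shown leave open whether the aromatic ring itself or its methoxy group accounts for these steps, a question that a plain phenyl group would help to answer. As far as these compounds go, how another group on that ring, such as an amine or a carboxylic acid, would read also remains open.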